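Branching on the acid chain and a quinoline ether series

The compounds below may be only part of what the source reports. "The series", "measured", "known", "first", "only" and "open" are said of these compounds alone.

The measured compounds:
Compound 1, `O=C(O)CCCCc1cccc(OCc2ccc3ccccc3n2)c1`: in an assay on membranes from lung (Cavia porcellus) for binding affinity to cysteinyl leukotriene receptor (Homo sapiens) (on this read-out lower numbers stand for stronger inhibition and higher numbers for weaker inhibition), compound 1 gives 100 nM.
Compound 2, `CC(CCCc1cccc(OCc2ccc3ccccc3n2)c1)C(=O)O`: in this assay compound 2 gives 85 nM.
Compound 3, `CC(Cc1cccc(OCc2ccc3ccccc3n2)c1)CC(C)C(=O)O`: in this assay compound 3 gives 24 nM.

Compound 3 stands lowest of the three numbers in this assay; its nearest neighbour is compound 2, and the step of a 3.5-fold lower number from compound 2 to compound 3 (0.55 log units; beyond the scatter) lies beyond the scatter, as does a 4.2-fold lower number from compound 1 to compound 3 (0.62 log units; beyond the scatter). The change a 1.2-fold lower number from compound 1 to compound 2 (0.07 log units; within the scatter), by contrast, stays within the scatter.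

Compound 4, `CCCC(CCC(=O)O)Cc1cccc(OCc2ccc3ccccc3n2)c1`, has not yet been measured. It differs from compound 3 by 1-(2-carboxyethyl)butyl in place of 3-carboxy-1-methylbutyl on a saturated chain carbon bound to an aromatic carbon. For the measured compounds named here, two measured steps bear on this: the gain on adding a methyl to a chain carbon bound to two saturated chain carbons, a 3.5-fold lower number from compound 2 to compound 3 (0.55 log units; beyond the scatter), and the indifference to the methyl on the carbon bound to the carbonyl, a 1.2-fold lower number from compound 1 to compound 2 (0.07 log units; within the scatter). Compound 4 keeps a branch on the chain, now a larger one, while giving up the methyl that made little difference. The account therefore expects compound 4 to stay close to compound 3, with a step of a 1.3-fold higher number from compound 3 to compound 4 (0.10 log units; within the scatter) that need not exceed the scatter. Compound 4 is estimated at 30 nM in this assay, within a range of 10 nM to 90 nM.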

Compound 4, inhibition constant: 50 nM
Beside the measured number, compound 4's estimate is 1.7-fold (0.22 log units) below it; measured number inside the range.
By their numbers in this assay, from the lowest: compound 3; then compounds 4, 2 and 1 (each within the scatter of the next).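

In this assay, for the compounds shown here, the exchange of 3-carboxy-1-methylbutyl for 1-(2-carboxyethyl)butyl on a saturated chain carbon bound to an aromatic carbon is the first sign that this position separates one branched chain from another (a 2.1-fold higher number from compound 3 to compound 4 (0.32 log units; beyond the scatter)), so having a branch is not enough to match compound 3. Compound 4 also stays within the scatter of the less branched chains, both for the added propyl branch (a 2.0-fold lower number from compound 1 to compound 4 (0.30 log units; within the scatter)) and for the exchange against 3-carboxybutyl (a 1.7-fold lower number from compound 2 to compound 4 (0.23 log units; within the scatter)), so among these four compounds only compound 3 stands clear of compound 1 and compound 2. Nothing available accounts for the difference between the two branched chains.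

The compounds shown leave open whether a methyl or an ethyl in place of the propyl branch of compound 4 would come closer to compound 3. They also leave open whether a longer chain, or an amide or a tetrazole in place of the carboxylic acid, would be tolerated at this position.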